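Acetyl to tert-butyl swap on two cores

The source may report more compounds than this note shows. Statements on the series, on what has been measured and on what is new or still open speak of the compounds shown alone.

Compound 1 `CC(=O)c1ccc(OCCCN2CCN(c3ncccn3)CC2)cc1`: in a functional assay on L5178Y cells (Mus musculus) for cytotoxicity, read by MTT assay (on this read-out lower numbers stand for stronger inhibition and higher numbers for weaker inhibition), compound 1 gives > 100 nM, which is a limit of the assay and not a number.
Compound 2 `CC(C)(C)c1ccc(OCCCN2CCN(c3ncccn3)CC2)cc1`: compound 2 gives 40.4 nM.
Compound 3 `CC(=O)c1ccc(OCCCCN2CCN(c3ccccn3)CC2)cc1`: compound 3 gives 63.7 nM.

Between compound 1 and compound 2 the change is tert-butyl in place of acetyl on an aromatic carbon; it gave an at least 2.4-fold lower number from compound 1 to compound 2 (0.39 log units; beyond the scatter). Note that one of the three values sits at the limit of > 100 nM in this assay, at which 1 of the 3 values shown sits, so the true size of that step is open at the top. Compound 3 and compound 2 lie within the scatter of each other, and no order is read between them. The core of compound 3 differs from the core of compound 1 in a way not broken down here.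

Compound 4 `CC(C)(C)c1ccc(OCCCCN2CCN(c3ccccn3)CC2)cc1` is not yet measured. Relative to compound 3 the change is tert-butyl in place of acetyl on an aromatic carbon, and the place is described in the same words as for the first pair, so this is the same change on the second core. Resting on an at least 2.4-fold lower number from compound 1 to compound 2 (0.39 log units; beyond the scatter), the step from compound 3 to compound 4 is expected to be about a 2.3-fold lower number from compound 3 to compound 4 (0.36 log units; beyond the scatter). Compound 4 is therefore estimated at 28 nM, expected to fall between 12 nM and 70 nM.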

Compound 4, half-maximal inhibitory concentration: 15.1 nM
Compound 4: the middle estimate sits 1.9-fold (0.27 log units) above what was measured, within the range that was stated.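

On the second core, tert-butyl in place of acetyl on an aromatic carbon gives a 4.2-fold lower number from compound 3 to compound 4 (0.63 log units; beyond the scatter) in this assay, so the direction of the change carries over to the core of compound 3. Set beside the first pair, the two steps cannot be ranked by size: the same change on two cores in this assay, an at least 2.4-fold lower number (0.39 log units; beyond the scatter) from compound 1 to compound 2 and a 4.2-fold lower number (0.63 log units; beyond the scatter) from compound 3 to compound 4; the limit leaves it open whether they differ
Compound 1 gives > 100 nM, which is a limit of the assay and not a number, so the two pairs support a shared direction but no fixed size for the step, and they show nothing about cores beyond these two.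

From the compounds shown here alone, only acetyl and tert-butyl appear at this place on the ring, so it remains open how other groups there, such as an amine or a carboxylic acid, would compare. Going by these compounds, the core of compound 1 and the core of compound 3 differ in a way not broken down here, and what a longer chain would do on either core also remains open.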